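Halogen swap on the benzamide of compound 1

The source may hold more compounds than are shown below. What is called first, only, known or untested is meant among the compounds shown, and "the series" means these compounds.

Going by the values given here, compound 1 `NC(=O)c1c(NC(=O)c2ccccc2Cl)sc2c1CCN(C(=S)Nc1ccccc1C(F)(F)F)C2` is the stronger of the two compounds measured so far in a functional assay on MKN-74 cells (Homo sapiens) for antiproliferative activity, with a stated time of 24 h (a lower number here means a stronger inhibitor, a higher number a weaker inhibitor), where compound 1 gives 1870 nM and compound 2 `COc1ccccc1NC(=S)N1CCc2c(sc(NC(=O)c3ccccc3Cl)c2C(N)=O)C1` gives 35200 nM. Among the compounds with values here, the one measured step, a 19-fold higher number from compound 1 to compound 2 (1.27 log units; beyond the scatter), concerns methoxy in place of trifluoromethyl on the thiourea aryl group, a different place from the change now considered. Compound 3 `NC(=O)c1c(NC(=O)c2ccccc2Br)sc2c1CCN(C(=S)Nc1ccccc1C(F)(F)F)C2` differs from compound 1 by bromo in place of chloro on an aromatic carbon. Within the data shown here, no measured step touches the halogen of the benzamide, so nothing indicates a shift beyond the scatter for this change in this assay. The step from compound 1 to compound 3 is expected to be small, a 1.2-fold lower number from compound 1 to compound 3 (0.07 log units; within the scatter), with no clear direction. Compound 3 is therefore estimated at 1600 nM in this assay, with a range from 600 nM to 4500 nM.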

Compound 3, half-maximal inhibitory concentration: 24300 nM
Estimate against measurement, compound 3: 15-fold (1.18 log units) below, and the stated range ends below it.
By their numbers in this assay, from the lowest: compound 1; then compounds 3 and 2 (each within the scatter of the next).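

The benzamide halogen, on an aromatic carbon ortho to a large group, proves sensitive in this assay: bromo in place of chloro gives a 13-fold higher number from compound 1 to compound 3 (1.11 log units; beyond the scatter), although the swap exchanges one heavy atom for one and leaves the hydrogen-bond donor, acceptor and charge counts unchanged. The series therefore has a second position with a large step, alongside the earlier change on the thiourea aryl group, and the chloro of compound 1 is preferred over bromo at this place. Nothing available accounts for the size of this step.

Still open, from the compounds shown here alone, is how the number responds to other groups at this place, such as fluoro, methyl or an amine, or to a plain phenyl without a halogen. Also open, going by these compounds, is whether the halogen swap has the same size when methoxy replaces trifluoromethyl on the thiourea aryl group.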